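The source may report more compounds than this note shows. Statements on the series, on what has been measured and on what is new or still open speak of the compounds shown alone.

Compound 1 `Cc1cc2c(cc1C)C(Cl)=C(/C=N/NC(=O)c1ccccc1)CCC2`: in a functional assay on HeLa cells (Homo sapiens) for inhibition, read by sulforhodamine B assay, with a stated time of 48 h (a lower number here means a stronger inhibitor of growth, a higher number a weaker inhibitor of growth), compound 1 gives > 100000 nM, which is a limit of the assay and not a number.
Compound 2 `Cc1cc2c(cc1C)C(Cl)=C(/C=N/NC(=O)c1cccc(Cl)c1)CCC2`: in this assay compound 2 gives 770 nM.
Compound 3 `Cc1cc2c(cc1C)C(Cl)=C(/C=N/NC(=O)c1cccc(I)c1)CCC2`: in this assay compound 3 gives > 100000 nM, again a limit of the assay and not a number.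

Compound 3 therefore stands at the edge of what this assay reports, and it is not alone there: the limit of > 100000 nM in this assay, at which 2 of the 3 values shown sit. The move to compound 4 `Cc1cc2c(cc1C)C(Cl)=C(/C=N/NC(=O)c1cccc(C(F)(F)F)c1)CCC2` is trifluoromethyl in place of iodo on an aromatic carbon, on an aromatic carbon of a six-membered aromatic ring of carbon only, meta to a large group. Among the measured compounds shown here, two measured steps bear on this position. One is an at least 120-fold higher number from compound 2 to compound 3 (2.11 log units; beyond the scatter); the other is an at least 120-fold lower number from compound 1 to compound 2 (2.11 log units; beyond the scatter). The third, a step that the two limits leave unreadable from compound 1 to compound 3, cannot be read. Among the three measured compounds only the chloro compound gives a number, while the hydrogen and iodo compounds both reach the limit. A trifluoromethyl at this position has no measured neighbour, so its direction is open. Compound 4 is estimated to give 20000 nM, between 800 nM and 150000 nM, which would mean an expected step of an at least 5.0-fold lower number from compound 3 to compound 4 (0.69 log units; beyond the scatter).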

Compound 4, concentration for 50% growth inhibition: 6800 nM
Compound 4: middle estimate off by 2.9-fold (0.47 log units), on the high side; measured number inside the range.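

Compound 4 shows that a readable number at this position in this assay is not confined to chloro: the change to trifluoromethyl gives an at least 14-fold lower number from compound 1 to compound 4 (1.16 log units; beyond the scatter), and replacing iodo gives an at least 14-fold lower number from compound 3 to compound 4 (1.16 log units; beyond the scatter). Chloro nevertheless remains ahead of trifluoromethyl, with an 8.8-fold higher number from compound 2 to compound 4 (0.95 log units; beyond the scatter), so two substituents now give numbers that can be ordered at this position. The hydrogen and iodo compounds remain the only ones that reach the assay's limit, which is not a number: the limit of > 100000 nM in this assay, at which 2 of the 4 values shown sit.

The compounds shown leave open whether an amine, a methoxy group or a nitrile at this position would give a number near that of compound 2 or reach the same limit. They also give no measured basis for explaining why trifluoromethyl gives a number while iodo does not.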